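The source may report more compounds than this note shows. Statements on the series, on what has been measured and on what is new or still open speak of the compounds shown alone.

Of the compounds shown here, three of a shared core have been measured in a functional assay on MCF7 cells (Homo sapiens) for cytotoxicity, read by sulforhodamine B assay, with a stated time of 48 h; on this read-out lower numbers stand for stronger inhibition of growth and higher numbers for weaker inhibition of growth. Compound 1 `COc1cc(-c2ccc(C)n2-c2ccc(-c3nc4ccccc4s3)cc2)cc(OC)c1OC` gives 2340 nM, which is the highest of the three numbers, though its neighbours lie within the scatter: compound 3 `COc1ccc(-c2ccc(C)n2-c2ccc(-c3nc4ccc(F)cc4s3)cc2)cc1` gives 2120 nM, and compound 2 `Cc1ccc(-c2ccc(F)cc2)n1-c1ccc(-c2nc3ccc(F)cc3s2)cc1` gives 1790 nM. For the measured compounds named here, the one single-point step among them, a 1.2-fold higher number from compound 2 to compound 3 (0.07 log units; within the scatter), shows that swapping a substituent on the outer aryl ring left the read-out essentially where it was.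

Compound 4 `COc1cc(-c2ccc(C)n2-c2ccc(-c3nc4ccc(F)cc4s3)cc2)cc(OC)c1OC` is the next step from compound 1: fluoro in place of hydrogen on an aromatic carbon, which turns the 1,3-benzothiazol-2-yl group into a 6-fluoro-1,3-benzothiazol-2-yl group. Going by the values given here, no measured pair isolates this change. Compounds 2 and 3 already carry the fluorinated benzothiazole, and their values sit within the scatter of compound 1, while compound 1 and compound 3 differ in two places at once, so their values can only hint that the fluorine is not decisive. Among the compounds with values here, the one step on record, a 1.2-fold higher number from compound 2 to compound 3 (0.07 log units; within the scatter), was itself within the scatter. Compound 4 is therefore expected to show no movement beyond the scatter in this assay, with a 1.1-fold lower number from compound 1 to compound 4 (0.03 log units; within the scatter) as the estimated step. The estimate for compound 4 is 2200 nM, with a range from 1100 nM to 4400 nM.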

Compound 4, concentration for 50% growth inhibition: 1410 nM
Beside the measured number, compound 4's estimate is 1.6-fold (0.19 log units) above it, and the stated range covers the measured number.
By their numbers in this assay, from the lowest: compounds 4, 2, 3 and 1 (each within the scatter of the next).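

In this assay, for the compounds shown here, the step on the benzothiazole ring of the shared core is now isolated for the first time: going from 1,3-benzothiazol-2-yl to 6-fluoro-1,3-benzothiazol-2-yl gives a 1.7-fold lower number from compound 1 to compound 4 (0.22 log units; within the scatter). The earlier compounds shown here could only hint at the role of this fluoro, since no pair among them differed at this place alone, whereas this single-atom change on the core of compound 1 gives a direct reading, and that reading does not separate the two compounds beyond the scatter. No measurement at hand bears on what lies behind this result.

The compounds shown leave open whether a different group at this same place, such as an amine, a carboxylic acid or a longer chain, would move the read-out beyond the scatter, since fluoro and hydrogen are the only two substituents compared here. They also leave open whether the same exchange of hydrogen for fluoro would read alike with the outer aryl rings of compound 2 and compound 3, for which no partner with the unsubstituted 1,3-benzothiazol-2-yl group is shown.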